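The source may hold more compounds than are shown below. What is called first, only, known or untested is meant among the compounds shown, and "the series" means these compounds.

Compound 1 `CCC[C@@H](CCO)Nc1nc(N)nc(C)c1Cc1ccc(CNCCC(N)=O)cc1OC`: in an assay on HEK293 cells for agonist activity at Toll-like receptor 8 (Homo sapiens) (on this read-out higher numbers stand for an effect only at larger amounts of compound and lower numbers for an effect already at smaller amounts), compound 1 sits at a limit, > 10000 nM.
Compound 2 `CCC[C@@H](CCO)Nc1nc(N)nc(C)c1Cc1ccc(CNC)cc1OC`: in this assay compound 2 gives 6460 nM.
Compound 3 `CCC[C@@H](CCO)Nc1nc(N)nc(C)c1Cc1ccc(CNC2CN(C)C2)cc1OC`: in this assay compound 3 sits at a limit, > 10000 nM.

Compound 3 thus stands at the limit of > 10000 nM in this assay, at which 2 of the 3 values shown sit, with no number of its own. Compound 4 `CCC[C@@H](CCO)Nc1nc(N)nc(C)c1Cc1ccc(CNC2CNC2)cc1OC` differs from compound 3 by hydrogen in place of methyl on an amine nitrogen in a ring. The steps that touch this part of the molecule are an at least 1.5-fold higher number from compound 2 to compound 3 (0.18 log units; that floor lies within the scatter) and a step that the two limits leave unreadable from compound 1 to compound 3; neither removes a methyl from the ring nitrogen, and both end at a limit. Since compound 3 itself sits at the limit of > 10000 nM in this assay, at which 2 of the 3 values shown sit, the move to compound 4 is expected to give no readable step beyond the scatter, a step that the limit leaves unreadable from compound 3 to compound 4. Compound 4 is therefore estimated at 15000 nM, between 5000 nM and 50000 nM, most likely again reported only as a limit.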

Compound 4, half-maximal effective concentration: > 10000 nM
Compound 4: no number, only a limit; the forecaster's own chance of this, stated with the estimate: 70%; the middle value lies beyond the limit too.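

With hydrogen in place of methyl on the ring nitrogen, compound 4 still gives no number in this assay, only a limit, > 10000 nM. For the compounds shown here, the one step that can be read is an at least 1.5-fold higher number from compound 2 to compound 4 (0.18 log units; that floor lies within the scatter), while the steps to compound 4 from compound 1 and compound 3 join two limits and cannot be read. Azetidin-3-yl thus joins 1-methylazetidin-3-yl at the same limit, with or without the methyl: the limit of > 10000 nM in this assay, at which 3 of the 4 values shown sit.

As far as these compounds go, how far compound 3 and compound 4 lie beyond that limit stays open. So does whether an ethyl group or a piperidin-4-yl group on the same amine nitrogen would give a readable value.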